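Compound 3 at its limit, and a larger group

This account rests on a few compounds, and the source may have more. Where it says the series, first, only, none or still open, it means among the compounds named here.

In a functional assay on A549 cells (Homo sapiens) for cytotoxicity, read by MTT assay, with a stated time of 6 days (a higher number here means that more compound is needed for the effect, a lower number that less compound is needed), compound 1 (`O=c1cc(-c2ccc([N+](=O)[O-])cc2)oc2cc(O)ccc12`) gives 21.8 ug/mL and compound 2 (`Nc1ccc(-c2cc(=O)c3cc(O)ccc3o2)cc1`) gives 2.72 ug/mL, the lower of these two numbers. Compound 3 (`COc1cc(-c2cc(=O)c3ccc(O)cc3o2)cc(OC)c1OC`) gives no exact number in this assay, only the limit > 25 ug/mL. Compound 4 (`COc1cc(-c2cc(=O)c3ccc(O)cc3o2)cc(OC)c1O[Si](C)(C)C(C)(C)C`) differs from compound 3 on an oxygen on an aromatic ring: a group of 7 heavy atoms (6 carbon, 1 silicon; no ring) in place of one carbon atom, on an oxygen on an aromatic ring. Among the compounds with values here, no measured step between compounds sizes such a change, so the expectation is loose: a modest move toward a lower number, with a real chance of a result again at the limit. The estimated change is an at least 1.7-fold lower number from compound 3 to compound 4 (0.25 log units; that floor lies within the scatter), though this remains uncertain. Compound 4 is expected at 14 ug/mL, with an estimated range of 4 ug/mL to 25 ug/mL.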

Compound 4, concentration for half-maximal effect: 5.3 ug/mL
For compound 4 the middle estimate is 2.6-fold (0.42 log units) above the measured one, within the range that was stated.
By their numbers in this assay, from the lowest: compounds 2 and 4 (each within the scatter of the next); then compound 1. At a limit, above all of these: compound 3.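

In this assay, within the data shown here, replacing methyl with a group of 7 heavy atoms on an oxygen on an aromatic ring gives the first measured step at this place (an at least 4.7-fold lower number from compound 3 to compound 4 (0.67 log units; beyond the scatter)). The change brings the number off the limit and beyond the scatter, so this place can affect the result. The step is only a minimum because compound 3 stands at a limit: the limit of > 25 ug/mL in this assay, at which 1 of the 4 values shown sits.

As far as these compounds go, it remains open whether a free hydroxyl or an ethyl on this oxygen would move the number too. From the compounds shown here alone, it also remains open whether an all-carbon group of similar size would match the silicon-bearing group.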